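Naphthyl amide with trifluoromethylsulfonamide: compound 3

The source may hold more compounds than are shown below. What is called first, only, known or untested is meant among the compounds shown, and "the series" means these compounds.

Two measured compounds frame the step. In a functional assay on SK-BR-3 cells (Homo sapiens) for antiproliferative activity, read by MTT assay, with a stated time of 48 h (on this read-out lower numbers stand for stronger inhibition and higher numbers for weaker inhibition), compound 2 `COc1ccc(OC)c(COc2cc(NC(=O)c3ccc(OC)c(OC)c3)ccc2N(C)S(=O)(=O)C(F)(F)F)c1` gives 550 nM, the higher of the two numbers. Among the measured compounds shown here, compound 1 `COc1ccc(OC)c(COc2cc(NC(=O)c3ccc4ccccc4c3)ccc2N(C)S(C)(=O)=O)c1` gives 16.6 nM, a clearly lower number, beyond the scatter; compound 1 and compound 2 differ in two places, so no single step is written between them. Compound 3 `COc1ccc(OC)c(COc2cc(NC(=O)c3ccc4ccccc4c3)ccc2N(C)S(=O)(=O)C(F)(F)F)c1` is not yet measured in this assay. It arises from compound 2 by naphthalen-2-yl in place of 3,4-dimethoxyphenyl on a carbonyl carbon, and it shares the naphthalen-2-yl amide of compound 1 while keeping the trifluoromethylsulfonyl group of compound 2. A lower number than for compound 2 is expected, since compound 1, the only naphthyl amide measured, gives 16.6 nM. The expected step of a 12-fold lower number from compound 2 to compound 3 (1.09 log units; beyond the scatter) is set to exceed the scatter but to stop short of the number of compound 1. For compound 3 the estimate is 45 nM, within a range of 12 nM to 200 nM.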

Compound 3, half-maximal inhibitory concentration: 200 nM
Estimate against measurement, compound 3: 4.4-fold (0.65 log units) below; measured number inside the range.
By their numbers in this assay, from the lowest: compound 1; then compound 3; then compound 2.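

In this assay the carbonyl position now has a single-place reading: naphthalen-2-yl in place of 3,4-dimethoxyphenyl gives a 2.8-fold lower number from compound 2 to compound 3 (0.44 log units; beyond the scatter) on the trifluoromethylsulfonyl background. Among the compounds shown here, the sulfonyl position can also be read for the first time, as trifluoromethyl in place of methyl on a sulfonyl sulfur gives a 12-fold higher number from compound 1 to compound 3 (1.08 log units; beyond the scatter) with the naphthalen-2-yl amide held constant. Of these two steps, the modest one is on the carbonyl carbon and the large one on the sulfonyl sulfur, and each is seen on one background only.

Going by these compounds, whether the naphthalen-2-yl step carries over to the methylsulfonyl form remains open, as does the effect of an ethyl group on the sulfonyl sulfur or a pyridine ring on the carbonyl carbon. No measured property bears on either step, so neither can be assigned a cause.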